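A New Phenyl Group on Compound 2

The compounds below may be only part of what the source reports. "The series", "measured", "known", "first", "only" and "open" are said of these compounds alone.

Compound 1 `Nc1nc(NCCNc2ncc(-c3ncc[nH]3)c(-c3ccc(F)cc3Cl)n2)ccc1[N+](=O)[O-]` and compound 2 `Nc1nc(NCCNc2ncc(-c3ncc[nH]3)c(-c3cc(F)c(Cl)cc3Cl)n2)ccc1[N+](=O)[O-]` share a core and differ in one phenyl group. In an ADME assay on microsomes from liver (Canis lupus familiaris) for metabolic stability (on this read-out lower numbers stand for a shorter-lived compound and higher numbers for a longer-lived compound), compound 1 gives > 0.5 h, which is a limit of the assay and not a number. Compound 2 gives > 0.5 h, which is also a limit, so its true half-life is not known.

Compound 3 `Cc1cc(Cl)ccc1-c1nc(NCCNc2ccc([N+](=O)[O-])c(N)n2)ncc1-c1ncc[nH]1` keeps the shared core but carries 4-chloro-2-methylphenyl in place of 2,4-dichloro-5-fluorophenyl on an aromatic carbon.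

For the measured compounds named here, one measured step bears on this change: a step that the two limits leave unreadable from compound 1 to compound 2. Its size cannot be read because of the limit of > 0.5 h in this assay, at which 2 of the 2 values shown sit. Going by the values given here, no measured step therefore points to a direction or a size for the new change, so no shift beyond the usual scatter is expected in this assay. The estimated step is a step that the limit leaves unreadable from compound 2 to compound 3. Compound 3 may well return a limit too. If it gives a number, the expected half-life of compound 3 is 0.6 h, with an estimated range from 0.3 h to 1.2 h.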

Compound 3, half-life: > 0.5 h
Compound 3 ended at the assay's limit; the forecaster's own chance of this, stated with the estimate: 70%; the middle value lies beyond the limit too.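

In this assay compound 3 gives > 0.5 h, which is a limit and not a number. The steps among compound 1, compound 2 and compound 3 therefore cannot be read, because all three values share one limit: the limit of > 0.5 h in this assay, at which 3 of the 3 values shown sit. The compounds shown leave open the true half-life of each compound and whether changing the phenyl group alters it.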